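Changing the Aryl Group on the Amide Carbonyl

This account rests on a few compounds, and the source may have more. Where it says the series, first, only, none or still open, it means among the compounds named here.

Three analogues built on one shared core have been measured in a functional assay on A549 cells (Homo sapiens) for antiproliferative activity, read by CCK-8 assay, with a stated time of 72 h; on this read-out lower numbers stand for stronger inhibition and higher numbers for weaker inhibition. Compound 1 `O=C(Nc1cccc(-c2oc3cc(-c4ccc(F)cc4)ccc3c(=O)c2O)c1)c1ccc(F)cc1` gives 6930 nM. Compound 2 `O=C(Nc1cccc(-c2oc3cc(-c4ccc(F)cc4)ccc3c(=O)c2O)c1)c1ccc(Br)cc1F` gives 46100 nM, and compound 3 `Cc1cc(C(=O)Nc2cccc(-c3oc4cc(-c5ccc(F)cc5)ccc4c(=O)c3O)c2)ccc1F` gives 11500 nM. Compound 3 holds the second highest number of the three; the step of a 1.7-fold higher number from compound 1 to compound 3 (0.22 log units; within the scatter) lies within the scatter, whereas a 4.0-fold lower number from compound 2 to compound 3 (0.60 log units; beyond the scatter) lies beyond it. The widest step seen so far is a 6.7-fold higher number from compound 1 to compound 2 (0.82 log units; beyond the scatter).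

Compound 4 `COc1cc(OC)cc(C(=O)Nc2cccc(-c3oc4cc(-c5ccc(F)cc5)ccc4c(=O)c3O)c2)c1` has not yet been measured. It differs from compound 3 by 3,5-dimethoxyphenyl in place of 4-fluoro-3-methylphenyl on a carbonyl carbon. For the measured compounds named here, the steps that bear on this change are those in which the aryl group on the carbonyl carbon was exchanged: a 6.7-fold higher number from compound 1 to compound 2 (0.82 log units; beyond the scatter) and a 4.0-fold lower number from compound 2 to compound 3 (0.60 log units; beyond the scatter), both modest and pointing in opposite directions. Neither of them involved a dimethoxy pattern, so the data do not fix the direction for compound 4. Since exchanges at this position have shifted the number by modest amounts either way, compound 4 is expected to show a step of a 1.3-fold higher number from compound 3 to compound 4 (0.12 log units; within the scatter), staying close to its parent or drifting somewhat higher. The estimate for compound 4 is 15000 nM, with a range from 5000 nM to 45000 nM.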

Compound 4, half-maximal inhibitory concentration: 2390 nM
Estimate against measurement, compound 4: 6.3-fold (0.80 log units) above, and the stated range ends above it.
By their numbers in this assay, from the lowest: compound 4; then compounds 1 and 3 (each within the scatter of the next); then compound 2.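

The result shows that the aryl group on the carbonyl carbon can move the number down as well as up, since a 2.9-fold lower number from compound 1 to compound 4 (0.46 log units; beyond the scatter) goes beyond the scatter, whereas the earlier exchanges gave no lower number than that of the 4-fluorophenyl amide. Against the other two amides the drop is wider still: a 4.8-fold lower number from compound 3 to compound 4 (0.68 log units; beyond the scatter) and a 19-fold lower number from compound 2 to compound 4 (1.29 log units; beyond the scatter) make the last the widest step in the series, and with all three steps beyond the scatter, compound 4 is the most potent of the four in this assay. For the compounds shown here, the 3,5-dimethoxyphenyl group is also the only aryl group here without fluorine, and it brings hydrogen-bond acceptors that 4-fluoro-3-methylphenyl lacks, but nothing available explains the gain or ties it to either feature.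

The compounds shown leave open whether both methoxy groups are needed or a single one would give the same number, and whether the gain depends on the oxygen atoms or would survive with plain methyl groups in their place. They also leave open how this position would respond to a hydroxyl group, an amine or a carboxylic acid on the aryl ring.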